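Trimming a cyclopropylmethyl to methyl on the shared core

The compounds below may be only part of what the source reports. "The series", "measured", "known", "first", "only" and "open" are said of these compounds alone.

Measured compounds:
Compound 1, `N#Cc1c(-c2ccc3c(ccn3CC3CC3)c2)ccn2c(CC(F)(F)F)cnc12`: 230%
Compound 2, `N#Cc1c(-c2ccc3c(c2)OCCN3)ccn2c(CC(F)(F)F)cnc12`: 232%
Compound 3, `N#Cc1c(-c2cc(Cl)c3c(ccn3CC3CC3)c2)ccn2c(CC(F)(F)F)cnc12`: 200%

In a functional assay on CHO cells for agonist activity at metabotropic glutamate receptor 2 (Homo sapiens) (on this read-out higher numbers stand for larger maximal responses and lower numbers for smaller maximal responses), compound 1 gives 230%, the second highest of the three numbers. Compound 2 lies within the scatter of compound 1, so no order between the two can be read. Compound 3 sits furthest away: a number 30 percentage points lower from compound 1 to compound 3 (beyond the scatter).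

Compound 4, `Cn1ccc2cc(-c3ccn4c(CC(F)(F)F)cnc4c3C#N)ccc21`, has not yet been measured in this assay. It differs from compound 1 in one place: hydrogen in place of cyclopropyl on a saturated chain carbon bound to an aromatic nitrogen. Read one bond further out, the change is cyclopropylmethyl to methyl.

None of the measured steps touches this group; the only step shown, the chloro step from compound 1 to compound 3, concerns an aromatic carbon and was modest. With nothing bearing directly on the change, compound 4 is expected to stay close to compound 1, and the estimated step is a number 10 percentage points lower from compound 1 to compound 4 (within the scatter), no further than the scatter. The estimate for compound 4 is therefore 220%, within 180% to 260%.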

Compound 4, largest response reached (Emax), in percent of the reference or control that the assay uses: 154%
Beside the measured number, compound 4's estimate is 66 percentage points above it, outside the stated range (below it).
By their numbers in this assay, from the lowest: compound 4; then compound 3; then compounds 1 and 2 (each within the scatter of the next).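

In this assay, the place that carries the cyclopropyl, a saturated chain carbon bound to an aromatic nitrogen, proves sensitive: cyclopropylmethyl to methyl gives a number 76 percentage points lower from compound 1 to compound 4 (beyond the scatter) as a large step, whereas the chloro step on an aromatic carbon, a number 30 percentage points lower from compound 1 to compound 3 (beyond the scatter) and only modest. The maximal response of the shared core therefore depends strongly on what this chain carbon carries, and compound 4, with hydrogen in place of the cyclopropyl, shows that the group cannot simply be trimmed away here. Nothing available explains why the response falls with this change.

The compounds shown leave open whether the three-membered ring itself matters or whether chain size alone is enough. An ethyl, a propyl or a cyclobutylmethyl group at this place would begin to separate those two readings.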